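This account rests on a few compounds, and the source may have more. Where it says the series, first, only, none or still open, it means among the compounds named here.

Among the compounds with values here, in a functional assay on MIA PaCa-2 cells (Homo sapiens) for inhibition, read by MTT assay, with a stated time of 48 h, tested at 10 uM (a lower number here means less inhibition of growth, a higher number more inhibition of growth at the concentration tested), compound 2 `CN1CC[C@H](c2c(O)cc(O)c3c(=O)cc(/C=C/c4cccc(F)c4)oc23)[C@H](O)C1` gives 67%, the higher of the two numbers so far, while compound 1 `CN1CC[C@H](c2c(O)cc(O)c3c(=O)cc(/C=C/c4cccc(Cl)c4)oc23)[C@H](O)C1` gives 52%. The next structure, compound 3 `CN1CC[C@H](c2c(O)cc(O)c3c(=O)cc(/C=C/c4ccccc4F)oc23)[C@H](O)C1`, has the same atoms as compound 2, joined differently: 2-fluorophenyl in place of 3-fluorophenyl on a double-bonded chain carbon bound to a double-bonded chain carbon. Within the data shown here, only one measured step bears on this change, a number 15 percentage points higher from compound 1 to compound 2 (beyond the scatter). That step is modest but beyond the scatter, and it exchanges chloro for fluoro, so it shows that this assay can respond to a change on this phenyl group. Among the measured compounds shown here, no measured pair tests the 2-fluorophenyl against the 3-fluorophenyl, so the data give no firm direction. A change no larger than the modest step seen for compound 2 is expected, with a slight drop as the working guess. The expected change is a number 7 percentage points lower from compound 2 to compound 3 (within the scatter), which is estimated to stay within the scatter. For compound 3, the estimated value is 60%, with an expected range from 45% to 75%.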

Compound 3, percent growth inhibition at one concentration: 60%
Estimate against measurement, compound 3: no gap at the digits printed; low and high end bracket the measured number.
By their numbers in this assay, from the lowest: compounds 1, 3 and 2 (each within the scatter of the next, the first and the last beyond it).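

Exchanging 3-fluorophenyl for 2-fluorophenyl on a double-bonded chain carbon bound to a double-bonded chain carbon gives a number 7 percentage points lower from compound 2 to compound 3 (within the scatter) in this assay and so does not separate these two groups. Set against 3-chlorophenyl, 2-fluorophenyl gives a number 8 percentage points higher from compound 1 to compound 3 (within the scatter) in the same read-out, so compound 3 cannot be told apart from compound 1 either, although a number 15 percentage points higher from compound 1 to compound 2 (beyond the scatter) lies beyond the scatter. Nothing measured here explains these numbers or accounts for any of these steps.

The compounds shown leave open whether an unsubstituted phenyl, or a phenyl carrying methoxy, nitrile or an amine, would keep growth inhibition in this range. On these data alone, it also remains open whether the difference between fluoro and chloro would recur on a 2-substituted phenyl group.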